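Sulfamoyl for Cyclohexyloxycarbonyl on the Pyrrolidine Amine

A few compounds are considered here, and "the series" means these few. Any claim that something is new, unique, unknown or untested is made for them only; others in the source may bear on it.

Measured compounds in an ADME assay on microsomes from liver (Mus musculus) for metabolic stability, read by LC-MS, with NADPH named in the record, with a stated time of 60 min, tested at 1 uM, in the absence of a further agent; on this read-out lower numbers stand for a less stable compound and higher numbers for a more stable compound:
Compound 1 `COc1ccc(-c2c(C)sc3c(N4CC[C@@H](NC(C)=O)C4)nc(C)nc23)cc1OC` gives > 95%, a limit of the assay.
Compound 2 `CC(=O)N[C@@H]1CCN(c2cc(C)nn3c(-c4ccc(OC(F)(F)F)cc4)c(C)nc23)C1` gives > 95%, likewise a limit.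
Compound 3 `COc1ccc(-c2c(C)nc3c(N4CC[C@@H](NC(=O)OC5CCCCC5)C4)cc(C)nn23)cc1OC` gives > 95%, again a limit.

In this assay compound 3 therefore stands only at a limit, not at a number; the same holds for the other two values, so that (the limit of > 95% in this assay, at which 3 of the 3 values shown sit). For the measured compounds named here, no step between measured compounds differing in one place is available. Compound 4 `COc1ccc(-c2c(C)nc3c(N4CC[C@@H](NS(N)(=O)=O)C4)cc(C)nn23)cc1OC` differs from compound 3 in one place: sulfamoyl in place of cyclohexyloxycarbonyl on an amine nitrogen. For compound 4 the change from compound 3 is expected to bring no step beyond the usual scatter, namely a number at least 2 percentage points lower from compound 3 to compound 4 (that floor lies within the scatter). Compound 4 is accordingly estimated at 93%, within 80% to 99%.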

Compound 4, percent of the compound remaining: > 95%
Compound 4: only a limit was reported; the forecaster's own chance of this, stated with the estimate: 60%; at least 2 percentage points between middle value and limit.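

In this assay compound 3 and compound 4 both stand at a limit, so no step between them can be read: the limit of > 95% in this assay, at which 4 of the 4 values shown sit.

The compounds shown leave open whether sulfamoyl in place of cyclohexyloxycarbonyl on an amine nitrogen changes the read-out in this assay at all.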